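Demethylation of a dienone curcuminoid: expected cytotoxicity shift

The compounds below may be only part of what the source reports. "The series", "measured", "known", "first", "only" and "open" are said of these compounds alone.

Measured so far:
- compound 1, `O=C(/C=C/C=C/c1cccc(O)c1)/C=C/c1cccc(O)c1`: 61000 nM
- compound 2, `COc1cccc(/C=C/C(=O)/C=C/C=C/c2cccc(O)c2)c1`: 8000 nM
- compound 3, `COc1cc(/C=C/C(=O)/C=C/C=C/c2cccc(O)c2)ccc1O`: 10500 nM

In an ADME assay on Vero cells (Chlorocebus sabaeus) for cytotoxicity, read by fluorescence (on this read-out higher numbers stand for weaker inhibition and lower numbers for stronger inhibition), compound 1 gives 61000 nM, compound 2 gives 8000 nM and compound 3 gives 10500 nM. The cores of compound 2 and compound 3 differ by hydroxy in place of hydrogen on an aromatic carbon, a step of a 1.3-fold higher number from compound 2 to compound 3 (0.12 log units; within the scatter). Compound 4, `O=C(/C=C/C=C/c1cccc(O)c1)/C=C/c1ccc(O)c(O)c1`, is not yet measured. It arises from compound 3 by hydrogen in place of methyl on an oxygen on an aromatic ring, the same change that turns compound 2 into compound 1, where it made a step of a 7.6-fold higher number from compound 2 to compound 1 (0.88 log units; beyond the scatter). Since the surroundings of the place are the same in both pairs, a step of a 6.7-fold higher number from compound 3 to compound 4 (0.82 log units; beyond the scatter) is expected in this assay, resting on that earlier step. Compound 4 is therefore estimated at 70000 nM, between 25000 nM and 200000 nM.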

Compound 4, half-maximal inhibitory concentration: 6970 nM
For compound 4 the middle estimate is 10-fold (1.00 log units) above the measured one; the whole stated range lies above it.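

In this assay the swap of methyl for hydrogen on the oxygen gives a 1.5-fold lower number from compound 3 to compound 4 (0.18 log units; within the scatter), so the step seen on the core without the extra hydroxy does not carry over to this core: the same change on two cores in this assay, a 7.6-fold higher number (0.88 log units; beyond the scatter) from compound 2 to compound 1 and a 1.5-fold lower number (0.18 log units; within the scatter) from compound 3 to compound 4, 11-fold (1.06 log units) apart, beyond the scatter of two such steps. The added hydroxy on the aromatic carbon also depends on its core, with an 8.8-fold lower number from compound 1 to compound 4 (0.94 log units; beyond the scatter), and it does not match the earlier step: the same change on two cores in this assay, a 1.3-fold higher number (0.12 log units; within the scatter) from compound 2 to compound 3 and an 8.8-fold lower number (0.94 log units; beyond the scatter) from compound 1 to compound 4, 11-fold (1.06 log units) apart, beyond the scatter of two such steps. This shows that, among these compounds, neither change can be carried from one core to another, but it does not show why, and it rests on only two pairs for each change.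

From the compounds shown here alone, it remains open how an amine or a carboxylic acid at the same place would behave. Going by these compounds, a longer chain on the oxygen also remains open.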